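Changing the Sulfonyl Aryl Group: Compound 1 to Compound 3

The source may hold more compounds than are shown below. What is called first, only, known or untested is meant among the compounds shown, and "the series" means these compounds.

Measured compounds:
compound 1, `O=S(=O)(Nc1ccc(-c2nc3ccccc3o2)cc1)c1cccc(Cl)c1`, 54000 nM
compound 2, `O=S(=O)(Nc1ccc(-c2nc3ccccc3o2)cc1)c1cccc(C(F)(F)F)c1`, 57000 nM

In an assay on cells for inhibition of HSP60/HSP10 (Homo sapiens), with a stated time of 60 min (a higher number here means a weaker inhibitor, a lower number a stronger inhibitor), compound 1 gives 54000 nM, the lowest of the two numbers measured, though the gap to compound 2 is a 1.1-fold higher number from compound 1 to compound 2 (0.02 log units; within the scatter). Compound 3, `Cc1ccccc1S(=O)(=O)Nc1ccc(-c2nc3ccccc3o2)cc1`, has not been measured. It differs from compound 1 in one place: 2-methylphenyl in place of 3-chlorophenyl on a sulfonyl sulfur. Going by the values given here, the only measured step concerns a change at a different position of the same aryl group and stays within the scatter, so no step bearing directly on this change is known. Compound 3 is therefore expected to show at most a modest change, a 1.1-fold higher number from compound 1 to compound 3 (0.05 log units; within the scatter), with an estimated 60000 nM in this assay, ranging from 25000 nM to 150000 nM.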

Compound 3, half-maximal inhibitory concentration: 85000 nM
For compound 3 the middle estimate is 1.4-fold (0.15 log units) below the measured one, and the stated range covers the measured number.
By their numbers in this assay, from the lowest: compounds 1, 2 and 3 (each within the scatter of the next).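

In this assay, the step from the 3-chlorophenyl to the 2-methylphenyl group on the sulfonyl sulfur gives a 1.6-fold higher number from compound 1 to compound 3 (0.20 log units; within the scatter) and so does not separate the two compounds. The earlier pair differed only in the group carried at one ring position, whereas here both the group and its ring position differ, and the step still stays within the scatter.

On these data alone, whether an amine or a carboxylic acid on this aryl ring, or a longer chain in place of the ring, would give a step beyond the scatter remains open. No available evidence bears on this result.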